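Pyridinyl ureas in the maximal electroshock model: compound 4

This account rests on a few compounds, and the source may have more. Where it says the series, first, only, none or still open, it means among the compounds named here.

Compound 1 `O=C(Nc1ccncc1)Nc1c(Cl)cccc1Cl` gives 100 mg/kg in a functional assay on the whole organism with Mus musculus as the target, in the maximal electroshock model, with a stated time of 30 min (a lower number here means that less compound is needed, a higher number that more compound is needed for the effect), the lowest of the two numbers shown. Compound 3 `O=C(Nc1ccncc1)Nc1c(Cl)cc(Cl)cc1Cl` gives 300 mg/kg, and the step of a 3.0-fold higher number from compound 1 to compound 3 (0.48 log units; beyond the scatter) is modest. Compound 2 `CC(C)c1cccc(C(C)C)c1NC(=O)Nc1ccncc1` gives only a limit of the assay, > 300 mg/kg, so the limit of > 300 mg/kg in this assay, at which 1 of the 3 values shown sits, sets no number. Compound 4 `O=C(Nc1ccncc1)Nc1c(Cl)cccc1CO` differs from compound 1 by hydroxymethyl in place of chloro on an aromatic carbon. Among the compounds with values here, no measured step covers hydroxymethyl in place of chloro; the one measured step concerns chloro entering, and it was modest, so a step of at most modest size is expected in either direction. Compound 4 is therefore estimated at 150 mg/kg, between 50 mg/kg and 300 mg/kg, a step of a 1.5-fold higher number from compound 1 to compound 4 (0.18 log units; within the scatter) expected to stay near the scatter.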

Compound 4, minimum effective dose: > 300 mg/kg
Compound 4 was reported as a limit; the forecaster's own chance of this, stated with the estimate: 25%; middle value at least 2.0-fold (0.30 log units) away from the limit.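

On this aromatic carbon, ortho to a large group, hydroxymethyl in place of chloro gives an at least 3.0-fold higher number from compound 1 to compound 4 (0.47 log units; beyond the scatter) in this assay. Within the data shown here, the earlier compounds showed only chloro entering, never chloro leaving, so this is the first sign that the chloro group at this place cannot be exchanged freely. The value of compound 4 is a limit and not a number, so the step has no upper end: the limit of > 300 mg/kg in this assay, at which 2 of the 4 values shown sit.

The compounds shown leave open whether the loss goes with hydroxymethyl entering or with chloro leaving. As far as these compounds go, how a methyl, a methoxy or an amine on this carbon would read in this assay also stays open.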